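2-Chlorophenyl to 2-methoxyphenyl: expected shift

The source may report more compounds than this note shows. Statements on the series, on what has been measured and on what is new or still open speak of the compounds shown alone.

In a physicochemical assay for lipophilicity, read by HPLC, at pH 7.5 (a lower number here means a more polar compound, a higher number a more lipophilic compound), compound 1 `CC[C@@H](Nc1c(C#N)c(-c2ccc(-c3cccc(C)c3)cc2)nc2cnccc12)C(N)=O` gives 3, compound 2 `CC[C@@H](Nc1c(C#N)c(-c2ccc(-c3ccc(Cl)cc3)cc2)nc2cnccc12)C(N)=O` gives 3.1 and compound 3 `CC[C@@H](Nc1c(C#N)c(-c2ccc(-c3ccccc3Cl)cc2)nc2cnccc12)C(N)=O` gives 2.9. Compound 3 therefore stands within the scatter of both other compounds, as a number 0.10 log units lower from compound 1 to compound 3 (within the scatter) and a number 0.20 log units lower from compound 2 to compound 3 (within the scatter) show. The next compound is compound 4 `CC[C@@H](Nc1c(C#N)c(-c2ccc(-c3ccccc3OC)cc2)nc2cnccc12)C(N)=O`, and the change is methoxy in place of chloro on an aromatic carbon, ortho to a large group.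

The measured steps bear on this only indirectly. Along with a number 0.10 log units higher from compound 1 to compound 2 (within the scatter), the two steps above exchange one substituted phenyl for another, and all three stay small. Going by the values given here, no measured step exchanges chloro for methoxy, so the series offers no direct precedent. The entering methoxy does count one hydrogen-bond acceptor where chloro counts none, so a modest downward move in this assay is expected, with the expected step being a number 0.30 log units lower from compound 3 to compound 4 (within the scatter). Compound 4 is estimated at 2.6, with an expected range of 2.2 to 3.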

Compound 4, distribution coefficient: 2.7
Compound 4: middle estimate off by 0.10 log units, on the low side, within the range that was stated.
By their numbers in this assay, from the lowest: compounds 4, 3, 1 and 2 (each within the scatter of the next, the first and the last beyond it).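

In this assay the series now has a direct reading of methoxy in place of chloro ortho to a large group: the step is a number 0.20 log units lower from compound 3 to compound 4 (within the scatter) and so cannot be told apart from repeat scatter. Going by these compounds alone, the comparison with the 3-methylphenyl compound gives a number 0.30 log units lower from compound 1 to compound 4 (within the scatter) and is also within the scatter, whereas a number 0.40 log units lower from compound 2 to compound 4 (beyond the scatter) is the first step to clear it, although that step changes both the substituent and where it sits on the ring. No measurement is available here to explain the size of any of these steps.

On these data alone, whether a 4-methoxyphenyl group would track the 4-chlorophenyl group of compound 2 remains open, as this would separate the effect of the group from that of its place. Also open, as far as these compounds go, is how far an amine, a carboxylic acid or a longer chain ortho to a large group would move the number.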